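Fluoro for methoxy on the shared core: compound 4

The compounds below may be only part of what the source reports. "The series", "measured", "known", "first", "only" and "open" are said of these compounds alone.

Compound 1 `COc1ccc2[nH]c(-c3nc(-c4ccccc4)no3)cc2c1` and compound 2 `Fc1ccc2[nH]c(-c3nc(-c4ccccc4)no3)cc2c1` share one core and differ in a single group: compound 2 carries fluoro in place of methoxy on an aromatic carbon. In a functional assay on Jurkat cells (Homo sapiens) for antiproliferative activity, read by WST assay, with a stated time of 72 h (a higher number here means a weaker inhibitor, a lower number a stronger inhibitor), compound 1 gives only a limit of the assay, > 50000 nM. In this assay compound 2 gives 33800 nM. The step is an at least 1.4-fold lower number from compound 1 to compound 2 (0.17 log units; that floor lies within the scatter); its size is capped by the limit of > 50000 nM in this assay, at which 2 of the 3 values shown sit.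

Compound 3 `COc1ccc(-c2noc(-c3cc4cc(OC)ccc4[nH]3)n2)cc1` differs from compound 1 by methoxy in place of hydrogen on an aromatic carbon, so the two cores differ by that group alone. In this assay compound 3 gives only a limit of the assay, > 50000 nM. The step is a step that the two limits leave unreadable from compound 1 to compound 3.

Compound 4 `COc1ccc(-c2noc(-c3cc4cc(F)ccc4[nH]3)n2)cc1` has not yet been measured. It stands to compound 3 as compound 2 stands to compound 1: the same change, (fluoro in place of methoxy on an aromatic carbon), at the same place on the same ring of the core. The step from compound 3 to compound 4 in this assay is expected to be about an at least 1.2-fold lower number from compound 3 to compound 4 (0.09 log units; that floor lies within the scatter), resting on the earlier step, an at least 1.4-fold lower number from compound 1 to compound 2 (0.17 log units; that floor lies within the scatter), and on the two values that both sit at the same limit. For compound 4 in this assay the expected value is 40000 nM, with a range from 12000 nM to 120000 nM, and a fair chance that only a limit is reported.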

Compound 4, half-maximal inhibitory concentration: > 50000 nM
Compound 4: a limit, no number (the forecaster's own chance of this, stated with the estimate: 50%); middle value at least 1.2-fold (0.09 log units) away from the limit.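

In this assay compound 4 gives > 50000 nM, which is a limit of the assay and not a number. Going by these compounds alone, for methoxy in place of hydrogen on an aromatic carbon, the one step that can be read is an at least 1.4-fold higher number from compound 2 to compound 4 (0.17 log units; that floor lies within the scatter), while the steps that have a limit at both ends cannot be read. The result therefore neither confirms nor refutes that fluoro in place of methoxy carries from the core of compound 1 to the core of compound 3, because the values gather at the limit of the read-out: the limit of > 50000 nM in this assay, at which 3 of the 4 values shown sit.

From the compounds shown here alone, only compound 2 gives a number, 33800 nM, so it remains open whether an amine or a carboxylic acid at the same place on the shared core would give a readable value in this assay. Also open, going by these compounds, is whether fluoro in place of methoxy would give a readable step on a core that starts from a number rather than a limit.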